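Tetrazolyl pyridine carboxamides: branching the ring methyl

This account rests on a few compounds, and the source may have more. Where it says the series, first, only, none or still open, it means among the compounds named here.

Measured compounds:
- compound 1, `Cc1ccc(-c2cc(C)cc(C(=O)Nc3nn[nH]n3)n2)cc1`: 100%
- compound 2, `Cc1cc(C(=O)Nc2nn[nH]n2)nc(-c2ccc(N)cc2)c1`: 100%

Both values come from a functional assay on the whole organism with Rattus norvegicus as the target, at a dose of 3 mg/kg by the oral route; a higher number here means a stronger effect of the compound at the dose given, a lower number a weaker effect. In this assay, going by the values given here, compound 1 gives 100%, and compound 2 gives 100%; the one computed step, no change at the digits printed from compound 1 to compound 2 (within the scatter), keeps the read-out where it is. Compound 1 therefore stands level with compound 2 at the digits shown, at the top of the read-out scale, with no measured neighbour that sits lower.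

The next compound is compound 3, `Cc1ccc(-c2cc(CC(C)C)cc(C(=O)Nc3nn[nH]n3)n2)cc1`. Relative to compound 1 the change is isopropyl in place of hydrogen on a saturated chain carbon bound to an aromatic carbon. Among the compounds with values here, the only measured step, that from compound 1 to compound 2, swaps a group on the aromatic carbon, not on the saturated chain carbon, so it bears on this change only weakly; it shows that one substituent swap left the read-out unmoved. Since compound 1 already reads at the ceiling, no rise is possible; the expected step of a number 5 percentage points lower from compound 1 to compound 3 (within the scatter) is therefore none beyond the scatter, with the downside open. Compound 3 is expected to give 95%, within 70% to 100%.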

Compound 3, a percentage reported as inhibition, in the whole organism at one dose (the size of the read-out at that dose, not a potency): 52%
For compound 3 the middle estimate is 43 percentage points above the measured one; measured number outside the range, below it.
By their numbers in this assay, from the lowest: compound 3; then compounds 1 and 2 (each within the scatter of the next).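

In this assay, methyl to isobutyl, that is, isopropyl in place of hydrogen on a saturated chain carbon bound to an aromatic carbon, gives a number 48 percentage points lower from compound 1 to compound 3 (beyond the scatter). Compound 1 and compound 2 both sat at the top of the read-out scale, so they could not show whether a change lowers the effect at this dose; compound 3 shows that this one does, and that the saturated chain carbon is a place where the read-out can be lost. Nothing at hand bears on the reason for this loss.

The compounds shown leave open whether the loss belongs to isobutyl in particular or sets in with any extension of the methyl, which an ethyl or a straight propyl chain on the same carbon would help to settle. Also open, from the compounds shown here alone, is whether a group carrying a heteroatom at this place, such as an amine or a carboxylic acid on the chain, would hold the read-out at the ceiling, and how compound 3 behaves at other doses.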